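Compound 2: propyl to butyl on the shared core

The source may report more compounds than this note shows. Statements on the series, on what has been measured and on what is new or still open speak of the compounds shown alone.

Measured in a functional assay on M21 cells (Homo sapiens) for antiproliferative activity, read by sulforhodamine B assay, with a stated time of 48 h; on this read-out lower numbers stand for stronger inhibition and higher numbers for weaker inhibition:
- compound 1 `CCCN1CCN(c2ccc(S(=O)(=O)Oc3cccc(OC)c3)cc2)C1=O` gives 10000 nM
- compound 2 `CCCN1CCN(c2ccc(S(=O)(=O)Oc3ccc(OC)c(OC)c3)cc2)C1=O` gives 28000 nM
- compound 3 `CCCN1CCN(c2ccc(S(=O)(=O)Oc3ccc(OC)cc3)cc2)C1=O` gives 23000 nM

Compound 2 sits at the high end of these numbers, and two steps place it: a 1.2-fold lower number from compound 2 to compound 3 (0.09 log units; within the scatter) and a 2.8-fold higher number from compound 1 to compound 2 (0.45 log units; beyond the scatter). The next analogue is compound 4 `CCCCN1CCN(c2ccc(S(=O)(=O)Oc3ccc(OC)c(OC)c3)cc2)C1=O`, which carries methyl in place of hydrogen on a saturated chain carbon, three bonds along the chain from an amide-type nitrogen in a ring, the propyl to butyl change. Within the data shown here, no measured step touches this chain, so the data lack a direct precedent. All three steps concern methoxy substitution on the aromatic end, and they bear only indirectly by showing how narrow the spread is so far, as in a 2.3-fold higher number from compound 1 to compound 3 (0.36 log units; beyond the scatter). On that basis, no clear direction is expected in this assay, and a shift beyond the scatter is not expected. The estimated step is a 1.2-fold lower number from compound 2 to compound 4 (0.07 log units; within the scatter). For compound 4 the expected value is 24000 nM within an estimated range of 9000 nM to 60000 nM.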

Compound 4, half-maximal inhibitory concentration: > 100000 nM
Compound 4 gave a limit, no number; the forecaster's own chance of this, stated with the estimate: 15%; at least 4.1-fold (0.61 log units) between middle value and limit.
By their numbers in this assay, from the lowest: compound 1; then compounds 3 and 2 (each within the scatter of the next). At a limit, above all of these: compound 4.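

In this assay compound 4 gives > 100000 nM, which is a limit of the assay and not a number. Among these compounds, the alkyl chain on the shared core is therefore not a silent position: the first step to touch it, methyl in place of hydrogen on a saturated chain carbon, gives an at least 3.5-fold higher number from compound 2 to compound 4 (0.55 log units; beyond the scatter), while the earlier steps concerned only methoxy substitution on the aromatic end. This step is a bound and not a measured size, and it rests on: the limit of > 100000 nM in this assay, at which 1 of the 4 values shown sits.

On these data alone, whether butyl acts the same way with the aromatic ends of compound 1 and compound 3 remains open. Also open, as far as these compounds go, is how this assay reads an ethyl chain, a longer chain such as pentyl, or a chain ending in an amine or a carboxylic acid.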